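This account rests on a few compounds, and the source may have more. Where it says the series, first, only, none or still open, it means among the compounds named here.

Three compounds were measured in a functional assay on the whole organism (artery, strain albino) with Rattus norvegicus as the target, with a stated time of 60 min, at a dose of 10 mg/kg by the oral route; a higher number here means more inhibition at the dose given (going by the name of the read-out), a lower number less inhibition:

Compound 1, `CC1=C(C(=O)Nc2ccc(F)cc2)C(c2ccc([N+](=O)[O-])cc2)N=C(SCc2ccccc2)N1`: 12.3%
Compound 2, `CC1=C(C(=O)Nc2ccc(F)cc2)C(c2ccc([N+](=O)[O-])cc2)N=C(SCc2ccccc2Cl)N1`: 6.2%
Compound 3, `COc1ccc(C2N=C(SCc3ccccc3)NC(C)=C2C(=O)Nc2ccc(Br)cc2)cc1`: 5.6%

Compound 1 and compound 2 share the same core and differ in a single place: chloro in place of hydrogen on an aromatic carbon. In this assay this change gave a number 6.1 percentage points lower from compound 1 to compound 2 (within the scatter), so the two numbers do not separate the chloro from the hydrogen. Compound 3 has a different core from compound 1; the difference between the two cores is not broken down here. Its value lies within the scatter of both compound 1 and compound 2, so no order among the three can be read from these numbers.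

Compound 4, `COc1ccc(C2N=C(SCc3ccccc3Cl)NC(C)=C2C(=O)Nc2ccc(Br)cc2)cc1`, has not yet been measured. It stands to compound 3 as compound 2 stands to compound 1: chloro in place of hydrogen on an aromatic carbon. The two place descriptions read alike, so this is the same change made on a different core. Going by the values given here, the only measured guide is the step from the first pair, which stayed within the scatter. The step to compound 4 is expected to be a number 2.6 percentage points lower from compound 3 to compound 4 (within the scatter). That expectation rests on compound 3, which gave 5.6%, and on the measured step of a number 6.1 percentage points lower from compound 1 to compound 2 (within the scatter), which stayed within the scatter. Compound 4 is therefore expected to give 3%, with a likely range from -5% to 12%.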

Compound 4, a percentage reported as inhibition, in the whole organism at one dose (the size of the read-out at that dose, not a potency): 6.7%
Compound 4: middle estimate off by 3.7 percentage points, on the low side; the range from low to high includes it.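

On the core of compound 3, replacing a hydrogen with a chloro, which turns benzylsulfanyl into (2-chlorobenzyl)sulfanyl, gave a number 1.1 percentage points higher from compound 3 to compound 4 (within the scatter) in this assay. The same change on the core of compound 1 gave a number 6.1 percentage points lower from compound 1 to compound 2 (within the scatter), and the two steps cannot be told apart: the same change on two cores in this assay, a number 6.1 percentage points lower (within the scatter) from compound 1 to compound 2 and a number 1.1 percentage points higher (within the scatter) from compound 3 to compound 4, 7.2 percentage points apart, within the scatter of two such steps. Going by these compounds alone, this shows that the chloro does not separate from the hydrogen on either core, and that the two cores give no measurable sign of responding differently to the change, but it does not show that the chloro has no effect or that the change carries over unaltered, since both steps are too small to read and only two pairs are available.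

The compounds shown hold only a hydrogen or a chloro at this place on the ring, so it remains open whether a different group there, such as an amine or a carboxylic acid, would give a step large enough to compare between cores. From the compounds shown here alone, it also remains open whether a longer chain in place of the benzyl group would do so, and whether any of these changes would behave alike on both cores.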